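The compounds below may be only part of what the source reports. "The series", "measured", "known", "first", "only" and "open" are said of these compounds alone.

Measured so far:
Compound 1, `CCC(Oc1ccc(-n2cc(C(F)(F)F)cn2)cc1)c1ccc(C(=O)NCCC(=O)O)cc1`: 1.9
Compound 2, `CCCC(Oc1ccc(-n2cc(F)cn2)cc1)c1ccc(C(=O)NCCC(=O)O)cc1`: 2
Compound 3, `CCCC(Nc1cc(C)c(-n2cc(C(F)(F)F)cn2)c(C)c1)c1ccc(C(=O)NCCC(=O)O)cc1`: 2.2

All three were measured in a physicochemical assay for lipophilicity, using the shake flask method, at pH 7.4; on this read-out higher numbers stand for higher lipophilicity and lower numbers for lower lipophilicity. In this assay compound 1 gives 1.9, compound 2 gives 2 and compound 3 gives 2.2. These three numbers sit close together: compound 2 lies within the scatter of compound 1 on one side and of compound 3 on the other, so on the numbers shown compound 2 cannot be told apart from either neighbour.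

Compound 4, `CCCC(Oc1ccc(-n2cccn2)cc1)c1ccc(C(=O)NCCC(=O)O)cc1`, has not yet been measured. It differs from compound 2 in one place: hydrogen in place of fluoro on an aromatic carbon. For the measured compounds named here, no measured pair shows this same change, so its size is not known from the data here. Compound 4 is expected to give 1.8 in this assay, between 1.5 and 2.1. The step this estimate means, a number 0.20 log units lower from compound 2 to compound 4 (within the scatter), is expected to be small and downward, not beyond the scatter.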

Compound 4, distribution coefficient: 1.7
For compound 4 the middle estimate is 0.10 log units above the measured one; the range from low to high includes it.
By their numbers in this assay, from the lowest: compounds 4, 1, 2 and 3 (each within the scatter of the next, the first and the last beyond it).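

For the compounds shown here, compound 2 and compound 4 are the first pair here that differs in one place only, so the swap from 4-fluoro-1H-pyrazol-1-yl to 1H-pyrazol-1-yl can now be read directly in this assay, as a number 0.30 log units lower from compound 2 to compound 4 (within the scatter) for this one pair. At this place on the ring, then, the two compounds cannot be told apart in this assay, so this pair gives no sign that fluoro and hydrogen differ there. Nothing in the information shown explains the size of this step.

Going by these compounds, it remains open whether another group on this same carbon, such as chloro, a nitrile or a methyl, would give a step beyond the scatter. On these data alone, it is also open whether the same swap would read alike on a different core, such as that of compound 3.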